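The source may report more compounds than this note shows. Statements on the series, on what has been measured and on what is new or still open speak of the compounds shown alone.

Measured compounds:
compound 1, `CCOc1ccc2nc(C)cc(OCC(=O)Nc3cc(C)cc(C)c3)c2c1`: > 100000 nM
compound 2, `COc1ccc2nc(C)cc(OCCNc3cc(C)cc(C)c3)c2c1`: 31600 nM
compound 3, `COc1ccc2nc(C)cc(OCC(=O)Nc3cccc(C)c3)c2c1`: 39800 nM

All three were tested in a toxicity assay on HepG2 cells (Homo sapiens) for inhibition, read by CellTiter-Glo, with a stated time of 48 h; on this read-out higher numbers stand for weaker inhibition and lower numbers for stronger inhibition. Compound 1 gave only a limit in this assay, > 100000 nM, not a number. Compound 2 gives 31600 nM and compound 3 gives 39800 nM; these two values sit within the scatter of each other, so neither can be placed above or below the other. Compound 3 thus stands at the upper end of the two numbers that were actually obtained, the third result being a limit only.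

Compound 4, `COc1ccc2nc(C)cc(OCC(=O)NNC(=O)c3ccncc3)c2c1`, has not yet been measured. It differs from compound 3 in one place: ((pyridin-4-yl)carbonyl)amino in place of 3-methylphenyl on an amide-type nitrogen. Within the data shown here, no pair of measured compounds shows this change, so its effect cannot be read from the numbers at hand. The expectation is a shift toward weaker inhibition from compound 3 to compound 4 of a 2.0-fold higher number from compound 3 to compound 4 (0.30 log units; within the scatter), possibly beyond the scatter, with a real chance that only a limit is reported. Compound 4 is therefore estimated at 80000 nM, within a range from 30000 nM to 300000 nM.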

Compound 4, half-maximal inhibitory concentration: > 100000 nM
Compound 4 was reported as a limit (the forecaster's own chance of this, stated with the estimate: 50%); middle value at least 1.2-fold (0.09 log units) away from the limit.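

In this assay, among these compounds, ((pyridin-4-yl)carbonyl)amino in place of 3-methylphenyl on an amide-type nitrogen gives an at least 2.5-fold higher number from compound 3 to compound 4 (0.40 log units; beyond the scatter), so this position does respond to the group placed on it, which no earlier pair could show. Compound 4 gives > 100000 nM, which is a limit and not a number. The step is therefore only a minimum, and its true size cannot be read, as the result stops at the same limit as another compound: the limit of > 100000 nM in this assay, at which 2 of the 4 values shown sit.

The entering group brings a carbonyl, an extra nitrogen and a pyridine ring all at once, and the compounds shown do not separate their contributions to the step. On these data alone, it also remains open how this read-out would respond to a simple amine or a carboxylic acid on the same amide-type nitrogen.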